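A few compounds are considered here, and "the series" means these few. Any claim that something is new, unique, unknown or untested is made for them only; others in the source may bear on it.

Working notes on the series. Two cores each carry the same pair of side groups. Compound 3 `Cc1ncnc2c1c(-c1cccs1)cn2[C@@H]1O[C@H](CO)[C@@H](O)[C@H]1O` and compound 1 `C#Cc1cn([C@@H]2O[C@H](CO)[C@@H](O)[C@H]2O)c2ncnc(C)c12` share one core; compound 2 `COc1nc(N)nc2c1c(-c1cccs1)cn2[C@@H]1O[C@H](CO)[C@@H](O)[C@H]1O` and compound 4 `C#Cc1cn([C@@H]2O[C@H](CO)[C@@H](O)[C@H]2O)c2nc(N)nc(OC)c12` share the other, and the difference between the two cores is not broken down here. In an ADME assay on BJ cells (Homo sapiens), read by MTT assay, with a stated time of 72 h (on this read-out higher numbers stand for weaker inhibition and lower numbers for stronger inhibition), compound 3 sits at the limit of the read-out, > 100000 nM, and gives no number. Compound 1 gives 50 nM in this assay. The change between them, (ethynyl in place of thiophen-2-yl on an aromatic carbon), makes an at least 2000-fold lower number from compound 3 to compound 1 (3.30 log units; beyond the scatter); with one end at the limit of > 100000 nM in this assay, at which 1 of the 3 values shown sits, the true size of that step is known only as a floor. Compound 2 gives 99900 nM in this assay. The change from compound 2 to compound 4 is ethynyl in place of thiophen-2-yl on an aromatic carbon, the same change at the same place on the ring as before. The step from compound 2 to compound 4 is expected to be of similar size, a 500-fold lower number from compound 2 to compound 4 (2.70 log units; beyond the scatter), resting on the earlier step of an at least 2000-fold lower number from compound 3 to compound 1 (3.30 log units; beyond the scatter) and the starting value of compound 2, 99900 nM. Compound 4 is thus estimated at 200 nM, between 30 nM and 2000 nM.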

Compound 4, half-maximal inhibitory concentration: > 100000 nM
Compound 4: no number, only a limit; the forecaster's own chance of this, stated with the estimate: 3%; middle value at least 500-fold (2.69 log units) from the limit.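

In this assay compound 4 gives > 100000 nM which is a limit and not a number. The step therefore reads only as a number no lower from compound 2 to compound 4 (the limit leaves the size open) and cannot be read as a size. Ethynyl in place of thiophen-2-yl on an aromatic carbon therefore does not carry over unchanged between these two cores, and the large drop seen on the core of compound 1 is absent on the core of compound 4: the same change on two cores in this assay, an at least 2000-fold lower number (3.30 log units; beyond the scatter) from compound 3 to compound 1 and a number no lower (the limit leaves the size open) from compound 2 to compound 4, at least 2000-fold (3.30 log units) apart, beyond the scatter of two such steps. This rests on a single pair on each core and does not show how far compound 4 lies past the limit, nor does it give a rule for any other core, and compound 4 is not alone at that limit: the limit of > 100000 nM in this assay, at which 2 of the 4 values shown sit.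

The compounds shown leave open which part of the difference between the two cores removes the drop, since the amine and the methoxy group are not separated from each other. They also leave open whether a nitrile or a longer alkyne chain at the same place would behave like ethynyl on either core.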